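Chloro to methoxy on the anilino ring, second instance

A few compounds are considered here, and "the series" means these few. Any claim that something is new, unique, unknown or untested is made for them only; others in the source may bear on it.

Measured in a functional assay on RPMI18226 cells (Homo sapiens) for antiproliferative activity, read by sulforhodamine B assay, with a stated time of 48 h, tested at 10 uM; on this read-out higher numbers stand for more inhibition at the one concentration tested (going by the name of the read-out) and lower numbers for less inhibition:
compound 1 `O=C(Nc1ccccc1)c1c(-c2ccc(Cl)cc2)cc(-c2ccccc2)nc1Nc1ccc(Cl)cc1`: 53%
compound 2 `COc1ccc(Nc2nc(-c3ccccc3)cc(-c3ccc(Cl)cc3)c2C(=O)Nc2ccccc2)cc1`: 30%
compound 3 `Cc1ccc(NC(=O)c2c(-c3ccc(Cl)cc3)cc(-c3ccccc3)nc2Nc2ccc(Cl)cc2)cc1`: 58%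

Compound 1 and compound 3 differ by methyl in place of hydrogen on an aromatic carbon, and the step of a number 5 percentage points higher from compound 1 to compound 3 (within the scatter). Compound 1 and compound 2 differ by methoxy in place of chloro on an aromatic carbon; here the step of a number 23 percentage points lower from compound 1 to compound 2 (beyond the scatter). Compound 4 `COc1ccc(Nc2nc(-c3ccccc3)cc(-c3ccc(Cl)cc3)c2C(=O)Nc2ccc(C)cc2)cc1` is not yet measured and differs from compound 3 by methoxy in place of chloro on an aromatic carbon, the same change as from compound 1 to compound 2, at a place described in identical terms; the two cores differ by methyl in place of hydrogen on an aromatic carbon. Going by the values given here, the step of a number 23 percentage points lower from compound 3 to compound 4 (beyond the scatter) in this assay is expected to resemble the one prior instance, because a number 23 percentage points lower from compound 1 to compound 2 (beyond the scatter) is the only measured step of the same change. Compound 4 is therefore estimated at 35%, with a range of 18% to 52%.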

Compound 4, a percentage reported as inhibition, at one concentration (the size of the read-out at that concentration, not a potency): 79%
Compound 4: middle estimate off by 44 percentage points, on the low side, and the stated range ends below it.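

In this assay, methoxy in place of chloro gives a number 21 percentage points higher from compound 3 to compound 4 (beyond the scatter), so this change does not carry even in direction from the core of compound 1 to the core of compound 3: the same change on two cores in this assay, a number 23 percentage points lower (beyond the scatter) from compound 1 to compound 2 and a number 21 percentage points higher (beyond the scatter) from compound 3 to compound 4, 44 percentage points apart, beyond the scatter of two such steps

Read the other way, methyl in place of hydrogen gives a number 49 percentage points higher from compound 2 to compound 4 (beyond the scatter), so the size of that step depends on whether chloro or methoxy is present: the same change on two cores in this assay, a number 5 percentage points higher (within the scatter) from compound 1 to compound 3 and a number 49 percentage points higher (beyond the scatter) from compound 2 to compound 4, 44 percentage points apart, beyond the scatter of two such steps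

The two changes are therefore not additive across these four compounds, but with one pair on each core this does not show why, or how either change would behave on a further core.

On these data alone, it remains open whether the reversal persists with an amine in place of the methoxy or a carboxylic acid in place of the methyl. These read-outs, each taken at one concentration, also leave potency open.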